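Swapping the aryl group on a chalcone-lactone hybrid

The source may report more compounds than this note shows. Statements on the series, on what has been measured and on what is new or still open speak of the compounds shown alone.

Measured so far:
compound 1, `COc1ccccc1/C=C/C(=O)c1ccc(OCC(=O)N[C@H]2CCOC2=O)cc1`, 7240 nM
compound 2, `C=CCc1ccc(OCCSC(=S)N[C@H]2CCOC2=O)c(OC)c1`, > 64000 nM
compound 3, `O=C(CNc1ccccc1)N[C@H]1CCOC1=O`, > 64000 nM

Of the compounds shown here, three have been tested in a functional assay on PC-3 cells (Homo sapiens) for antiproliferative activity, read by MTT assay, with a stated time of 72 h; a lower number here means a stronger inhibitor, a higher number a weaker inhibitor. Compound 1 gives 7240 nM and is the only one with a numeric result. For compound 2 the reading of > 64000 nM is a limit of the assay, not a number. For compound 3 the reading of > 64000 nM is likewise a limit. Compound 1 therefore stands alone, with the other two sitting at the limit of > 64000 nM in this assay, at which 2 of the 3 values shown sit.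

The untested compound 4, `O=C(COc1ccc(C(=O)/C=C/c2cccc([N+](=O)[O-])c2)cc1)N[C@H]1CCOC1=O`, shares the core of compound 1 and differs in one place: 3-nitrophenyl in place of 2-methoxyphenyl on a double-bonded chain carbon bound to a double-bonded chain carbon. Among the measured compounds shown here, no pair of measured compounds shows the effect of such a swap, so there is no measured step to lean on. Both groups are single aromatic rings carried at the same chain position, and the expected shift in this assay is modest, in either direction, and likely within the scatter. Compound 4 is expected to give 6000 nM, between 1800 nM and 20000 nM. The step from compound 1 to compound 4 is estimated at a 1.2-fold lower number from compound 1 to compound 4 (0.08 log units; within the scatter).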

Compound 4, half-maximal inhibitory concentration: 56300 nM
Beside the measured number, compound 4's estimate is 9.4-fold (0.97 log units) below it; the whole stated range lies below it.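

Replacing 2-methoxyphenyl with 3-nitrophenyl on a double-bonded chain carbon bound to a double-bonded chain carbon gives a 7.8-fold higher number from compound 1 to compound 4 (0.89 log units; beyond the scatter) in this assay. Among the compounds shown here, this is the first single-place comparison, and it shows that the aryl group at this position is not interchangeable: two single aromatic rings at the same spot give clearly different antiproliferative readings. The readings of compound 2 and compound 3 are a limit and not numbers, so any larger weakening from a change at this position could no longer be sized: the limit of > 64000 nM in this assay, at which 2 of the 4 values shown sit.

This one swap changes both the substituent and where it sits on the ring, so the two effects cannot be separated. From the compounds shown here alone, how a plain phenyl or a 3-methoxyphenyl reads at this position remains open, and either could help tell those two effects apart.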